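A few compounds are considered here, and "the series" means these few. Any claim that something is new, unique, unknown or untested is made for them only; others in the source may bear on it.

Measured compounds in an ADME assay on HT-29 cells (Homo sapiens) for inhibition, read by MTT assay, with a stated time of 72 h; on this read-out higher numbers stand for weaker inhibition and lower numbers for stronger inhibition:
- compound 1, `C=CC(=O)Nc1cccc(Nc2nc(N/N=C/c3ccccc3F)ncc2Cl)c1`, gives 3500 nM
- compound 2, `C=CC(=O)Nc1cccc(Nc2nc(N/N=C(\C)c3ccc(OC)cc3)ncc2Cl)c1`, gives 4560 nM
- compound 3, `CN(C)C/C=C/C(=O)Nc1cccc(Nc2nc(N/N=C/c3ccccc3F)ncc2Cl)c1`, gives 3660 nM

Compound 3 stands second highest of the three numbers; its nearest neighbour is compound 1 and its furthest is compound 2, and both gaps lie within the scatter, so the three measured compounds cannot be ordered on this read-out.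

Compound 4, `C/C(=N\Nc1ncc(Cl)c(Nc2cccc(NC(=O)/C=C/CN(C)C)c2)n1)c1ccc(F)cc1`, is not yet measured. It differs from compound 3 in one place: a group of 10 heavy atoms (8 carbon, 1 nitrogen, 1 fluorine; one six-membered aromatic ring of carbon only) in place of a group of 9 heavy atoms (7 carbon, 1 nitrogen, 1 fluorine; one six-membered aromatic ring of carbon only), on a nitrogen on an aromatic ring. The group that enters carries one more carbon than the group that leaves and the fluorine sits elsewhere on its aromatic ring.

Going by the values given here, only one measured step is known, a 1.0-fold higher number from compound 1 to compound 3 (0.02 log units; within the scatter), and it concerns the other end of the shared core, not the hydrazone side. Among the compounds with values here, no step is recorded between compound 1 and compound 2; their two values differ only within the scatter although compound 2 already carries an extra carbon on the hydrazone carbon together with a different substituent on the aromatic ring. Nothing here points to a change beyond the scatter, so no directional step is expected in this assay.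

Compound 4 is therefore estimated at 4000 nM, range 2000 nM to 8500 nM, which means an expected step of a 1.1-fold higher number from compound 3 to compound 4 (0.04 log units; within the scatter).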

Compound 4, half-maximal inhibitory concentration: 10200 nM
Compound 4: middle estimate off by 2.6-fold (0.41 log units), on the low side; measured number outside the range, above it.
By their numbers in this assay, from the lowest: compounds 1, 3 and 2 (each within the scatter of the next); then compound 4.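

In this assay, going by these compounds alone, the group on a nitrogen on an aromatic ring gives the first step beyond the scatter, a 2.8-fold higher number from compound 3 to compound 4 (0.45 log units; beyond the scatter) and so this position responds to change, whereas the one earlier step, a 1.0-fold higher number from compound 1 to compound 3 (0.02 log units; within the scatter) at the other end of the shared core, stayed within it. The change joins two things, one more carbon in the entering group and the fluorine sitting elsewhere on its aromatic ring, and this single step cannot tell them apart. No measured evidence is at hand that bears on why the number rises.

From the compounds shown here alone, it remains open which of the two parts carries the step, and whether the same change would give a similar step on the vinyl amide of compound 1 as it does on the 3-(dimethylamino)prop-1-en-1-yl amide of compound 3. Also open, going by these compounds, is how far the trend runs at this position, for instance with an ethyl group in place of the added carbon or with chlorine in place of the fluorine.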